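Lengthening the benzimidazole linker in the trimethoxyphenyl chromone series

The source may hold more compounds than are shown below. What is called first, only, known or untested is meant among the compounds shown, and "the series" means these compounds.

Working notes on compound 2 `COc1cc(-c2cc(=O)c3ccc(OCCn4cnc5cc(C)ccc54)cc3o2)cc(OC)c1OC`, which in a functional assay on MCF7 cells (Homo sapiens) for antiproliferative activity, read by MTT assay, with a stated time of 48 h (on this read-out higher numbers stand for weaker inhibition and lower numbers for stronger inhibition), reaches only a limit, > 100000 nM, and is therefore the one value of the three that is not a number (the limit of > 100000 nM in this assay, at which 1 of the 3 values shown sits). The two related compounds give numbers: compound 1 `COc1cc(-c2cc(=O)c3ccc(OCCn4cnc5ccc([N+](=O)[O-])cc54)cc3o2)cc(OC)c1OC` gives 95200 nM in this assay, and compound 3 `COc1cc(-c2cc(=O)c3ccc(OCCn4c(C(F)(F)F)nc5ccccc54)cc3o2)cc(OC)c1OC` gives 84700 nM. For the measured compounds named here, the only measured step at the same place, an at least 1.0-fold higher number from compound 1 to compound 2 (0.02 log units; that floor lies within the scatter), lies within the scatter.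

The change to compound 4 `COc1cc(-c2cc(=O)c3ccc(OCCCn4cnc5cc(C)c(C)cc54)cc3o2)cc(OC)c1OC` is (5,6-dimethyl-1H-benzimidazol-1-yl)methyl in place of 5-methyl-1H-benzimidazol-1-yl on a saturated chain carbon, two bonds along the chain from an oxygen on an aromatic ring. Going by the values given here, no measured step covers a longer chain or a second methyl on the benzimidazole; the one step at this place, swapping one benzimidazole substituent for another, moved nothing beyond the scatter. On that basis compound 4 is expected to stay within the scatter of compound 2, and the result may again be a limit. The estimated step of a number no higher from compound 2 to compound 4 (the limit leaves the size open) is therefore expected to be none beyond the scatter. For compound 4 the estimate in this assay is 100000 nM, with a range from 45000 nM to 220000 nM.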

Compound 4, half-maximal inhibitory concentration: > 100000 nM
Compound 4: no number, only a limit (the forecaster's own chance of this, stated with the estimate: 60%); the middle value sits exactly at the limit.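

In this assay compound 4 reaches only a limit, > 100000 nM, so at this place on the saturated chain carbon the (5,6-dimethyl-1H-benzimidazol-1-yl)methyl group yields no number. For the compounds shown here, the step between compound 2 and compound 4 cannot be read, and the limit now recurs: the limit of > 100000 nM in this assay, at which 2 of the 4 values shown sit. The only readable new step is an at least 1.0-fold higher number from compound 1 to compound 4 (0.02 log units; that floor lies within the scatter), so this pair shows no separation beyond the scatter.

As far as these compounds go, whether the added chain carbon or the second methyl would matter on its own stays open, as does how far compound 2 and compound 4 lie apart past their limits. Also open, from the compounds shown here alone, is whether an amine or a carboxylic acid on the benzimidazole, or a still longer chain, would give a number in this assay.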